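Methyl Replaces Fluoro: Expected Efficacy of Compound 4

The compounds below may be only part of what the source reports. "The series", "measured", "known", "first", "only" and "open" are said of these compounds alone.

Measured so far:
compound 1 `CCCC(=O)N1CC2CC(C1)N2`, giving 120% in an assay on SH-EP1 cells for agonist activity at Neuronal acetylcholine receptor; alpha4/beta2 (Homo sapiens), read by FLIPR and calcium flux; on this read-out lower numbers stand for smaller maximal responses and higher numbers for larger maximal responses
compound 2 `O=C(C1CCC1)N1CC2CC(C1)N2`, giving 100%
compound 3 `O=C([C@H]1C[C@@H]1F)N1CC2CC(C1)N2`, giving 100%

Compound 3 sits level with compound 2 at the bottom of these three numbers, while compound 1 stands higher: a number 20 percentage points lower from compound 1 to compound 3 (beyond the scatter). Compound 4 `C[C@H]1C[C@@H]1C(=O)N1CC2CC(C1)N2` is the next candidate; its difference from compound 3 is methyl in place of fluoro on a saturated ring carbon. Within the data shown here, no measured step touches this ring substituent. The closest comparisons are no change at the digits printed from compound 2 to compound 3 (within the scatter) and a number 20 percentage points lower from compound 1 to compound 2 (beyond the scatter), both replacing the whole group on the carbonyl carbon, and they show that moving among these small groups shifts the maximal response modestly or not at all. Compound 4 is therefore expected to stay near compound 3, with no change at the digits printed from compound 3 to compound 4 (within the scatter). The estimate for compound 4 is 100%, ranging from 80% to 120%.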

Compound 4, largest response reached (Emax), in percent of the reference or control that the assay uses: 67%
Compound 4: middle estimate off by 33 percentage points, on the high side; the whole stated range lies above it.
By their numbers in this assay, from the lowest: compound 4; then compounds 2 and 3 (each within the scatter of the next); then compound 1.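

In this assay, this ring position proves sensitive: methyl in place of fluoro brings a large fall (a number 33 percentage points lower from compound 3 to compound 4 (beyond the scatter)), though each group counts one heavy atom and neither has hydrogen-bond donors or acceptors. The 2-methylcyclopropyl group also stands clearly apart from the cyclobutyl group (a number 33 percentage points lower from compound 2 to compound 4 (beyond the scatter)) and the propyl group (a number 53 percentage points lower from compound 1 to compound 4 (beyond the scatter)). No available evidence bears on this fall. The compounds shown leave open how a plain hydrogen, a hydroxyl or an ethyl group at this ring carbon would compare.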